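Chloro substitution on the phenoxy group of compound 2

This account rests on a few compounds, and the source may have more. Where it says the series, first, only, none or still open, it means among the compounds named here.

Measured compounds:
compound 1 `CCCSc1cc(C)c(C(=O)N=C(N)N)cc1S(C)(=O)=O`: 6.8 nM
compound 2 `Cc1cc(Oc2ccccc2)c(S(C)(=O)=O)cc1C(=O)N=C(N)N`: 10 nM

In a functional assay for inhibition of sodium/hydrogen exchanger (Oryctolagus cuniculus) (a higher number here means a weaker inhibitor, a lower number a stronger inhibitor), compound 2 gives 10 nM, the highest of the two numbers recorded; its nearest neighbour is compound 1, which gives 6.8 nM. Among the measured compounds shown here, the one measured step, a 1.5-fold higher number from compound 1 to compound 2 (0.17 log units; within the scatter), is within the scatter, so the two compounds cannot be ordered.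

Compound 3 `Cc1cc(Oc2cccc(Cl)c2)c(S(C)(=O)=O)cc1C(=O)N=C(N)N` differs from compound 2 by chloro in place of hydrogen on an aromatic carbon; read one bond further out, the phenoxy becomes a 3-chlorophenoxy. For the measured compounds named here, no measured step bears on this change: the only step known concerns the exchange of propylsulfanyl for phenoxy, and it was within the scatter. With nothing pointing in either direction, the step of a 1.3-fold lower number from compound 2 to compound 3 (0.10 log units; within the scatter) is expected to stay within the scatter. Compound 3 is therefore estimated at 8 nM in this assay, with a range from 3 nM to 25 nM.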

Compound 3, half-maximal inhibitory concentration: 21 nM
Compound 3: middle estimate off by 2.6-fold (0.42 log units), on the low side, within the range that was stated.
By their numbers in this assay, from the lowest: compounds 1 and 2 (each within the scatter of the next); then compound 3.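

In this assay the phenoxy ring proves sensitive to substitution: chloro in place of hydrogen on an aromatic carbon, meta to a large group, gives a 2.1-fold higher number from compound 2 to compound 3 (0.32 log units; beyond the scatter) and so moves the number beyond the scatter, which the exchange of propylsulfanyl for unsubstituted phenoxy did not do. Replacing propylsulfanyl with 3-chlorophenoxy likewise gives a 3.1-fold higher number from compound 1 to compound 3 (0.49 log units; beyond the scatter) and is also beyond the scatter, so this position tolerates phenoxy but not 3-chlorophenoxy equally well. Nothing available explains why the chloro raises the number.

The compounds leave open whether this rise is particular to chloro or would also follow from fluoro or methoxy at the same place on the ring. They also leave open how chloro would behave elsewhere on the phenoxy ring, and whether an amine or a longer chain in place of phenoxy would hold the number.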